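From 2,6-Dichlorophenyl to 2-Chlorophenyl in Compound 4

A few compounds are considered here, and "the series" means these few. Any claim that something is new, unique, unknown or untested is made for them only; others in the source may bear on it.

In a functional assay on HCT-116 cells (Homo sapiens) for inhibition, read by CCK-8 assay, with a stated time of 72 h (a lower number here means a stronger inhibitor, a higher number a weaker inhibitor), compound 1 `O=C(NO)c1ccc(CNC(=O)c2n[nH]cc2NC(=O)c2c(Cl)cccc2Cl)cc1` gives 500 nM, the lowest of the three numbers, although compound 2 `Nc1ccccc1NC(=O)c1ccc(CNC(=O)c2n[nH]cc2NC(=O)c2c(Cl)cccc2Cl)cc1`, at 710 nM, cannot be separated from it. Compound 3 `Nc1ccccc1NC(=O)c1ccc(CNC(=O)c2n[nH]cc2NC(=O)c2ccccc2F)cc1` reads 4800 nM, clearly apart from both.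

Compound 4 `O=C(NO)c1ccc(CNC(=O)c2n[nH]cc2NC(=O)c2ccccc2Cl)cc1` differs from compound 1 by hydrogen in place of chloro on an aromatic carbon, so that 2,6-dichlorophenyl becomes 2-chlorophenyl. The measured step of a 1.4-fold higher number from compound 1 to compound 2 (0.15 log units; within the scatter) concerns a different group and stays within the scatter, so it offers little guidance. The closer precedent is a 6.8-fold higher number from compound 2 to compound 3 (0.83 log units; beyond the scatter), where 2,6-dichlorophenyl also gives way, though to 2-fluorophenyl. Within the data shown here, compound 4 keeps one chloro, and no measured compound carries 2-chlorophenyl, so the comparison is imperfect. A move in the same direction is expected, but smaller than that precedent, and the estimated step is a 2.8-fold higher number from compound 1 to compound 4 (0.45 log units; beyond the scatter). For compound 4 the expected value is 1400 nM, with an estimated range of 600 nM to 3800 nM.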

Compound 4, half-maximal inhibitory concentration: 2400 nM
Estimate against measurement, compound 4: 1.7-fold (0.23 log units) below; measured number inside the range.
By their numbers in this assay, from the lowest: compounds 1 and 2 (each within the scatter of the next); then compounds 4 and 3 (each within the scatter of the next).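

In this assay the loss of one chloro, with nothing else altered, gives a 4.8-fold higher number from compound 1 to compound 4 (0.68 log units; beyond the scatter) and so shows that the change from 2,6-dichlorophenyl to 2-chlorophenyl is enough by itself to move the number beyond the scatter. Among these compounds, the earlier change on this ring, a 6.8-fold higher number from compound 2 to compound 3 (0.83 log units; beyond the scatter) and also a swap of chloro for fluoro, could not separate the loss of a chloro from the change of halogen, and it was seen only with the 2-aminophenyl amide; the new step isolates that loss and runs in the same direction with hydroxy on the amide-type nitrogen. Nothing available gives a reason for this step.

Whether the remaining chloro contributes also stays open, since plain phenyl does not appear among these compounds. It is equally unknown whether a methyl or methoxy group in place of the departed chloro would keep the number close to that of compound 1.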